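Changing the amide-side aryl group in a weakly cytotoxic series

The source may hold more compounds than are shown below. What is called first, only, known or untested is meant among the compounds shown, and "the series" means these compounds.

Of the compounds shown here, three sharing one core have been tested in an ADME assay on SW480 cells (Homo sapiens) for cytotoxicity, read by MTT assay, with a stated time of 72 h; a lower number here means a stronger inhibitor, a higher number a weaker inhibitor. Compound 1 `CCOc1ccc(NC(=O)c2cccc(/C=C3\CC(=O)N(c4ccccc4)C3=O)c2)cc1` gives 91500 nM in this assay. Compound 2 `CCc1cccc(NC(=O)c2cccc(/C=C3\CC(=O)N(c4ccccc4)C3=O)c2)c1` gives 88600 nM in this assay. Compound 3 `O=C(Nc1ccc(OC(F)F)cc1)c1cccc(/C=C2\CC(=O)N(c3ccccc3)C2=O)c1` gives only a limit of the assay, > 100000 nM. So compound 3 stands at a limit rather than at a number, namely (the limit of > 100000 nM in this assay, at which 1 of the 3 values shown sits). Compound 4 `O=C(Nc1cccc(F)c1)c1cccc(/C=C2\CC(=O)N(c3ccccc3)C2=O)c1` has not yet been measured; it differs from compound 3 in one place: 3-fluorophenyl in place of 4-(difluoromethoxy)phenyl on an amide-type nitrogen. Two measured steps likewise change the group on the amide-type nitrogen. The first is a 1.0-fold lower number from compound 1 to compound 2 (0.01 log units; within the scatter); the second is an at least 1.1-fold higher number from compound 2 to compound 3 (0.05 log units; that floor lies within the scatter). Neither step goes beyond the scatter, so no step beyond the scatter is expected here either. Compound 4 is therefore expected to give about 100000 nM in this assay, with a range from 50000 nM to 250000 nM. The expected step is a number no higher from compound 3 to compound 4 (the limit leaves the size open), and the result may well come back once more as a limit.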

Compound 4, half-maximal inhibitory concentration: > 100000 nM
Compound 4 was reported as a limit; the forecaster's own chance of this, stated with the estimate: 55%; the middle value lies on the limit itself.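

Compound 4 puts a fluoro-bearing ring with fewer heavy atoms on the amide-type nitrogen, and in this assay it too ends at a limit of the assay rather than a number, so the smaller group brings no readable gain. Its readable steps are an at least 1.1-fold higher number from compound 2 to compound 4 (0.05 log units; that floor lies within the scatter) and an at least 1.0-fold higher number from compound 1 to compound 4 (0.03 log units; that floor lies within the scatter), while the step between compound 3 and compound 4, both limits, cannot be read. The series now meets this ceiling more than once: the limit of > 100000 nM in this assay, at which 2 of the 4 values shown sit.

From the compounds shown here alone, whether an aryl ring carrying an amine or a carboxylic acid would move the number beyond the scatter stays open. Also open, going by these compounds, is how far past the limit compound 3 and compound 4 truly lie, and whether they differ from each other at all.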